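A few compounds are considered here, and "the series" means these few. Any claim that something is new, unique, unknown or untested is made for them only; others in the source may bear on it.

Compound 1, `COc1nc(C(C)(C)C)ccc1[C@@H](c1ccccc1)[C@@](O)(CCN(C)C)c1cccc2ccccc12`, is the anchor of this small set. Among the compounds with values here, in a toxicity assay on Vero cells (Chlorocebus sabaeus) for cytotoxicity (on this read-out lower numbers stand for higher toxicity in this test and higher numbers for lower toxicity in this test), compound 1 gives 27.6 ug/mL, the only value here that is a number rather than a limit. Compound 2, `COc1nc(-c2ccc(Br)cc2)ccc1[C@@H](c1ccccc1)[C@@](O)(CCN(C)C)c1cccc2ccccc12`, carries a 4-bromophenyl in place of the tert-butyl on an aromatic carbon. In this assay compound 2 gives > 50 ug/mL, which is a limit of the assay and not a number. For compound 2 this is the limit of > 50 ug/mL in this assay, at which 1 of the 2 values shown sits. The step between them is an at least 1.8-fold higher number from compound 1 to compound 2 (0.25 log units; that floor lies within the scatter), so no real change can be claimed from it.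

Compound 3, `COc1nc(-c2ccsc2)ccc1[C@@H](c1ccccc1)[C@@](O)(CCN(C)C)c1cccc2ccccc12`, has not been measured. It differs from compound 1 as follows: thiophen-3-yl in place of tert-butyl on an aromatic carbon. As with compound 2, an aromatic ring takes the place of the tert-butyl, and the step from compound 1 to compound 2 is the only one that bears on it. Given that step was an at least 1.8-fold higher number from compound 1 to compound 2 (0.25 log units; that floor lies within the scatter), a small rise in the number, or none beyond the scatter, is expected, with a fair chance that only a limit is returned. Compound 3 is estimated at 40 ug/mL, between 20 ug/mL and 80 ug/mL. That estimate means an expected step of a 1.4-fold higher number from compound 1 to compound 3 (0.16 log units; within the scatter).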

Compound 3, half-maximal cytotoxic concentration: 24.4 ug/mL
For compound 3 the middle estimate is 1.6-fold (0.21 log units) above the measured one, within the range that was stated.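

In this assay, thiophen-3-yl in place of tert-butyl gives a 1.1-fold lower number from compound 1 to compound 3 (0.05 log units; within the scatter), so at this place, next to the ring nitrogen, a five-membered aromatic ring and a tert-butyl group cannot be told apart in this test. Thiophen-3-yl in place of 4-bromophenyl at the same place gives an at least 2.0-fold lower number from compound 2 to compound 3 (0.31 log units; beyond the scatter), which is the first step at this position that goes beyond the scatter and shows that the two aromatic groups are not interchangeable here. The reading for compound 2 is a limit of the assay, so this step has a floor and not a known size: the limit of > 50 ug/mL in this assay, at which 1 of the 3 values shown sits.

The compounds shown leave open whether the gap between the two aromatic groups follows the bromine atom or the larger ring that carries it, and an unsubstituted phenyl or a 4-chlorophenyl at this place would separate those two readings. They also leave open how a thiophen-2-yl, a pyridine ring or a group holding an amine or a carboxylic acid would read at this place in this assay.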